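Catechol for Methoxy on a Bis-Benzylidene Cyclohexanone Core

A few compounds are considered here, and "the series" means these few. Any claim that something is new, unique, unknown or untested is made for them only; others in the source may bear on it.

Compounds with measured values:
compound 1, `COc1ccc(/C=C2\CCC/C(=C\c3ccc(OC)c(OC)c3)C2=O)cc1`, 7800 nM
compound 2, `COc1ccc(/C=C2\CCC/C(=C\c3ccc(OC)c(OC)c3)C2=O)c(OC)c1`, 15600 nM
compound 3, `COc1ccc(/C=C2\CCC/C(=C\c3ccc(OC)c(OC)c3)C2=O)cc1OC`, 13500 nM

The three compounds share one core and were tested in a functional assay on MCF7 cells (Homo sapiens) for cytotoxicity, read by MTT assay, with a stated time of 72 h; a higher number here means a weaker inhibitor, a lower number a stronger inhibitor. Compound 1 gives the lowest of the three numbers, but its neighbours sit close: the step of a 2.0-fold higher number from compound 1 to compound 2 (0.30 log units; within the scatter) and the step of a 1.7-fold higher number from compound 1 to compound 3 (0.24 log units; within the scatter) are both within the scatter, so no order among the three can be claimed.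

Compound 4, `COc1ccc(/C=C2\CCC/C(=C\c3ccc(O)c(O)c3)C2=O)cc1OC`, has not yet been measured in this assay. It differs from compound 1 in one place: 3,4-dihydroxyphenyl in place of 4-methoxyphenyl on a double-bonded chain carbon bound to a double-bonded ring carbon. Both measured steps concern a methoxy added to an aromatic carbon; neither concerns the removal of a methoxy or the entry of a hydroxyl, so neither bears directly on this change. What they do show is that small changes at the aromatic rings of this core moved the number in this assay by no more than the scatter. On that basis the step to compound 4 is expected to stay within the scatter as well, with no clear direction. Compound 4 is therefore estimated at 7000 nM, within the range 2500 nM to 20000 nM, which corresponds to an expected step of a 1.1-fold lower number from compound 1 to compound 4 (0.05 log units; within the scatter).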

Compound 4, half-maximal inhibitory concentration: 14400 nM
For compound 4 the middle estimate is 2.1-fold (0.31 log units) below the measured one; low and high end bracket the measured number.
By their numbers in this assay, from the lowest: compounds 1, 3, 4 and 2 (each within the scatter of the next).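

Putting 3,4-dihydroxyphenyl in place of 4-methoxyphenyl on a double-bonded chain carbon bound to a double-bonded ring carbon gives, in this assay, a 1.8-fold higher number from compound 1 to compound 4 (0.27 log units; within the scatter). Among the compounds shown here, this is the first step that removes a methoxy group and brings in hydroxyl groups: the group that leaves has no hydrogen-bond donors, the group that enters has two, and even so the step is no larger than the scatter, just as with the two earlier steps that added a methoxy. Nothing measured here offers a reason for this result, and no order can be drawn between compound 1 and compound 4.

The compounds shown leave open whether a ring bearing a single hydroxyl would give a number different from that of the ring bearing two, since the two hydroxyl groups enter together in compound 4 and their separate contributions cannot be told apart. They also leave open whether a larger departure at this place, such as an amine, a carboxylic acid or a longer alkoxy chain on the ring, would move the number beyond the scatter.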